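From Acetyl to Propylcarbonyl on a Shared Core

The source may report more compounds than this note shows. Statements on the series, on what has been measured and on what is new or still open speak of the compounds shown alone.

For the measured compounds named here, in a functional assay on the whole organism for positive allosteric modulation, with Mus musculus as the target (on this read-out lower numbers stand for an effect already at smaller amounts and higher numbers for an effect only at larger amounts of compound), compound 3 (`CC(=O)N(c1ccccc1)C1CCCC1N(C)C`) gives 40 mg/kg as the highest number among the compounds measured so far. Compound 1 (`CCC(=O)N(c1ccc(Cl)cc1)C1CCCCC1N(C)C`) gives 14 mg/kg in the same test, and that gap to compound 3 lies beyond the usual scatter. Compound 2 (`CCC(=O)N(c1ccc(C)cc1)C1CCCC1N(C)C`) gives 10 mg/kg; 10 mg/kg (2 entries) in both of its entries, within the scatter of compound 1.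

Compound 4 (`CCCC(=O)N(c1ccccc1)C1CCCC1N(C)C`) has not yet been measured. It has ethyl in place of hydrogen on a saturated chain carbon bound to a carbonyl carbon, which also reads as acetyl to propylcarbonyl. Going by the values given here, no measured pair shows this change alone. The expectation leans on compound 1 at 14 mg/kg and compound 2 at 10 mg/kg; 10 mg/kg (2 entries) as weak guides, since both carry a chain longer than acetyl on the carbonyl but also differ elsewhere. A modest move in this assay is expected, a 2.2-fold lower number from compound 3 to compound 4 (0.35 log units; beyond the scatter) toward a smaller dose. Compound 4 is estimated at 18 mg/kg with an expected range from 6 mg/kg to 50 mg/kg as its likely span.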

Compound 4, dose for half-maximal effect: 40 mg/kg
Compound 4: middle estimate off by 2.2-fold (0.35 log units), on the low side, within the range that was stated.
By their numbers in this assay, from the lowest: compound 1; then compounds 3 and 4 (each within the scatter of the next).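

Adding ethyl on a saturated chain carbon bound to a carbonyl carbon gives no change at the digits printed from compound 3 to compound 4 (within the scatter) in this assay, and this holds on the shared core. This is the first pair shown that differs in this one place alone, so acetyl to propylcarbonyl can now be read directly, and here the longer chain leaves the dose where it was. Nothing available explains why the number stays put.

Going by these compounds, whether a longer chain such as pentyl, or a carboxylic acid or an amine at the end of the chain, would leave the number equally unchanged remains open. On these data alone, compound 1 and compound 2 each differ from compound 3 in more than one place, so what their separate changes contribute also stays unknown.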